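Moving the amino group on a quinoxaline sulfone series

The source may report more compounds than this note shows. Statements on the series, on what has been measured and on what is new or still open speak of the compounds shown alone.

Compound 1 `Cc1ccc(S(=O)(=O)c2nc3ccccc3nc2Nc2ccc(N)cc2)cc1` gives 11500 nM in a functional assay on HCT-116 cells (Homo sapiens) for cytotoxicity, read by MTT assay, with a stated time of 72 h; on this read-out higher numbers stand for weaker inhibition and lower numbers for stronger inhibition. Compound 2 `Cc1ccc(S(=O)(=O)c2nc3ccccc3nc2Nc2cccc(N)c2)cc1` differs by 3-aminophenyl in place of 4-aminophenyl on a nitrogen on an aromatic ring and gives 2390 nM, a step of a 4.8-fold lower number from compound 1 to compound 2 (0.68 log units; beyond the scatter). Compound 3 `Nc1ccc(Nc2nc3ccccc3nc2S(=O)(=O)c2ccc(Br)cc2)cc1` carries a different core, differing from compound 1 by bromo in place of methyl on an aromatic carbon; in this assay compound 3 gives 1390 nM, a step of an 8.3-fold lower number from compound 1 to compound 3 (0.92 log units; beyond the scatter). Compound 4 `Nc1cccc(Nc2nc3ccccc3nc2S(=O)(=O)c2ccc(Br)cc2)c1` remains to be measured; it differs from compound 3 by 3-aminophenyl in place of 4-aminophenyl on a nitrogen on an aromatic ring, the same change that separates compound 1 from compound 2, at the same place on each core. From compound 3 to compound 4 a step of about a 3.5-fold lower number from compound 3 to compound 4 (0.54 log units; beyond the scatter) is expected, resting on the step of a 4.8-fold lower number from compound 1 to compound 2 (0.68 log units; beyond the scatter) seen on the other core, tempered somewhat. For the measured compounds named here, only that one precedent of the change is in hand, and a single precedent may overstate the effect. Compound 4 is therefore estimated at 400 nM, with a likely range from 150 nM to 1000 nM.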

Compound 4, half-maximal inhibitory concentration: 3280 nM
Compound 4: middle estimate off by 8.2-fold (0.91 log units), on the low side; measured number outside the range, above it.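

In this assay, the same move from 4-aminophenyl to 3-aminophenyl gives a 2.4-fold higher number from compound 3 to compound 4 (0.37 log units; beyond the scatter), so its direction on the core of compound 1 did not carry over to the bromo-bearing analogues: the same change on two cores in this assay, a 4.8-fold lower number (0.68 log units; beyond the scatter) from compound 1 to compound 2 and a 2.4-fold higher number (0.37 log units; beyond the scatter) from compound 3 to compound 4, 11-fold (1.06 log units) apart, beyond the scatter of two such steps. The change to bromo in place of methyl also fails to carry over, as a 1.4-fold higher number from compound 2 to compound 4 (0.14 log units; within the scatter) stays within the scatter: the same change on two cores in this assay, an 8.3-fold lower number (0.92 log units; beyond the scatter) from compound 1 to compound 3 and a 1.4-fold higher number (0.14 log units; within the scatter) from compound 2 to compound 4, 11-fold (1.06 log units) apart, beyond the scatter of two such steps. Neither change therefore acts as a fixed increment across these four compounds, though they do not show why the steps differ or how either change would behave elsewhere in the series.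

Going by these compounds, it remains open how the two aminophenyl groups would compare with a chloro or methoxy group in place of the bromo or methyl. On these data alone, whether a hydroxyl in place of the amino group would follow the same pattern also remains open.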